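Acetyl in place of pyrrolidinyl: weighing compound 3

This account rests on a few compounds, and the source may have more. Where it says the series, first, only, none or still open, it means among the compounds named here.

Compound 1 `O=[N+]([O-])c1ccc2[nH]c(-c3ccccc3N3CCCC3)nc2c1`: in a functional assay for antagonist activity at Neuropeptides B/W receptor type 1 (Homo sapiens), read by cAMP accumulation (on this read-out lower numbers stand for stronger inhibition and higher numbers for weaker inhibition), compound 1 gives 6770 nM.
Compound 2 `CC(=O)c1cccc(-c2nc3cc([N+](=O)[O-])ccc3[nH]2)c1`: in this assay compound 2 gives only a limit, > 31600 nM.

Compound 1 holds the only number shown; the other value is a limit, (the limit of > 31600 nM in this assay, at which 1 of the 2 values shown sits). Compound 3 `CC(=O)c1ccccc1-c1nc2cc([N+](=O)[O-])ccc2[nH]1` differs from compound 1 by acetyl in place of pyrrolidin-1-yl on an aromatic carbon. Going by the values given here, no step between measured compounds is known, so its size cannot be read off; a weakening beyond the scatter is expected, given that compound 2 also carries acetyl and sits at the limit of > 31600 nM in this assay, at which 1 of the 2 values shown sits. For compound 3 the estimate in this assay is 20000 nM, range 6000 nM to 60000 nM. That estimate means an expected step of a 3.0-fold higher number from compound 1 to compound 3 (0.47 log units; beyond the scatter).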

Compound 3, half-maximal inhibitory concentration: > 31600 nM
Compound 3: no number, only a limit; the forecaster's own chance of this, stated with the estimate: 45%; middle value at least 1.5-fold (0.19 log units) away from the limit.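

In this assay, acetyl in place of pyrrolidin-1-yl on an aromatic carbon, ortho to a large group, gives an at least 4.6-fold higher number from compound 1 to compound 3 (0.66 log units; beyond the scatter). Compound 3 gives only a limit, so this step is a bound and its full size cannot be read. Both acetyl compounds, compound 2 and compound 3, stand at a limit, and pyrrolidin-1-yl is the only group here with a number: the limit of > 31600 nM in this assay, at which 2 of the 3 values shown sit.

Open, as far as these compounds go, is whether dimethylamino, piperidin-1-yl or morpholin-4-yl at this place would keep the value of compound 1. The compounds shown also cannot separate losing the pyrrolidin-1-yl ring from gaining the carbonyl.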